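The source may report more compounds than this note shows. Statements on the series, on what has been measured and on what is new or still open speak of the compounds shown alone.

Series values in a functional assay on MCF7 cells (Homo sapiens) for inhibition, read by MTT assay, with a stated time of 72 h; a higher number here means a weaker inhibitor, a lower number a stronger inhibitor:
- compound 1 `FC(F)(F)c1ccc(CSc2nc(N3CCNCC3)cc(C(F)(F)F)n2)cc1`: 10700 nM
- compound 2 `FC(F)(F)c1ccc(CSc2nc(Sc3nnnn3-c3ccccc3)cc(C(F)(F)F)n2)cc1`: 39500 nM

Of the two measured compounds, compound 2 has the higher number and so is the weaker inhibitor, and its gap to compound 1 lies beyond the scatter.

Compound 3 `FC(F)(F)c1ccc(CSc2nc(Sc3nncs3)cc(C(F)(F)F)n2)cc1` is still unmeasured. It keeps the shared core and has 1,3,4-thiadiazol-2-yl in place of 1-phenyl-1H-tetrazol-5-yl on a sulfur. Within the data shown here, no measured pair isolates this change, so the expectation rests only on the two values, compound 1 at 10700 nM and compound 2 at 39500 nM. With compound 2 the higher of the two, a modest move towards a lower number is expected, with little confidence in its size. The expected change is a 1.8-fold lower number from compound 2 to compound 3 (0.25 log units; within the scatter). For compound 3 the estimated value in this assay is 22000 nM, with an expected range from 8000 nM to 60000 nM.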

Compound 3, half-maximal inhibitory concentration: 8810 nM
Compound 3: middle estimate off by 2.5-fold (0.40 log units), on the high side; the measured number falls inside the stated range.
By their numbers in this assay, from the lowest: compounds 3 and 1 (each within the scatter of the next); then compound 2.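

In this assay, the group on the sulfur now has a comparison that differs in one place: 1,3,4-thiadiazol-2-yl in place of 1-phenyl-1H-tetrazol-5-yl gives a clear step (a 4.5-fold lower number from compound 2 to compound 3 (0.65 log units; beyond the scatter)), so the higher number is not common to every aromatic group held on that sulfur. Against piperazin-1-yl on the same aromatic carbon, (1,3,4-thiadiazol-2-yl)sulfanyl gives no separable difference (a 1.2-fold lower number from compound 1 to compound 3 (0.08 log units; within the scatter)). No measurement on hand offers a reason for either step.

The change on the sulfur replaces the five-membered ring and also removes the six-membered aromatic ring of carbon only, and these two parts cannot be told apart here. Also open, as far as these compounds go, is how a carboxylic acid or a longer alkyl chain on that sulfur would read in this assay.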